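Urea nitrogen substituent swap on the chloropyridine benzothiazole series

This account rests on a few compounds, and the source may have more. Where it says the series, first, only, none or still open, it means among the compounds named here.

Three ureas and one amine of a shared core have been examined in a functional assay on MCF7 cells (Homo sapiens) for antiproliferative activity, read by MTT assay, with a stated time of 72 h; a lower number here means a stronger inhibitor, a higher number a weaker inhibitor. Compound 1 `COc1ncc(-c2ccc3nc(NC(=O)NC4CC4)sc3c2)cc1NS(=O)(=O)c1ccc(F)cc1` gives 1190 nM. Compound 2 `O=S(=O)(Nc1cc(-c2ccc3nc(NC4CC4)sc3c2)cnc1Cl)c1ccc(F)cc1` carries a cyclopropylamine rather than a urea, and in this assay compound 2 is recorded as "not determined" (no result reported). Compound 3 `CCN(CC)CCNC(=O)Nc1nc2ccc(-c3cnc(Cl)c(NS(=O)(=O)c4ccc(F)cc4)c3)cc2s1` gives 710 nM; its number and that of compound 1 lie within the usual scatter of each other, so no ordering between the two can be claimed, and no other single number is available for comparison.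

Compound 4 `O=C(Nc1nc2ccc(-c3cnc(Cl)c(NS(=O)(=O)c4ccc(F)cc4)c3)cc2s1)NC1CC1` is the next compound to be measured. Relative to compound 3 the change is cyclopropyl in place of 2-(diethylamino)ethyl on an amide-type nitrogen. Compound 1 already carries the cyclopropylcarbamoyl group on a core that differs elsewhere, and its value of 1190 nM sits close to compound 3. On that basis the step from the 2-(diethylamino)ethyl to the cyclopropyl group is expected to be small, if anything a slight weakening, and the estimated step is a 1.4-fold higher number from compound 3 to compound 4 (0.15 log units; within the scatter). For compound 4 the expected value in this assay is 1000 nM, with a range from 400 nM to 2500 nM.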

Compound 4, half-maximal inhibitory concentration: 1090 nM
Beside the measured number, compound 4's estimate is 1.1-fold (0.04 log units) below it, within the range that was stated.
By their numbers in this assay, from the lowest: compounds 3, 4 and 1 (each within the scatter of the next).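

In this assay, cyclopropyl in place of 2-(diethylamino)ethyl on the amide-type nitrogen gives a 1.5-fold higher number from compound 3 to compound 4 (0.19 log units; within the scatter), so these two groups cannot be told apart at this position, although one is an open chain carrying an amine nitrogen and the other a three-membered carbon ring. Chloro in place of methoxy on an aromatic carbon, with the cyclopropylcarbamoyl group held constant, gives a 1.1-fold lower number from compound 1 to compound 4 (0.04 log units; within the scatter), so these two substituents cannot be told apart either. No measurement at hand offers an explanation for either result.

Only two groups on the amide-type nitrogen and two on the aromatic carbon can be compared so far, so neither place is yet shown to influence the number. As far as these compounds go, it remains open whether a morpholine ring or a carboxylic acid on that nitrogen, or a fluoro or methyl group on that aromatic carbon, would give a step beyond the scatter.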